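Removing the methoxy on the phenoxy ring: acid dissociation

The compounds below may be only part of what the source reports. "The series", "measured", "known", "first", "only" and "open" are said of these compounds alone.

Measured so far:
compound 1 `COc1ccccc1Oc1ccc2c(NCCCNCc3ccco3)ccnc2c1`: 9.28
compound 2 `COc1ccc(Oc2ccc3c(NCCCNCc4cc(F)ccc4OC)ccnc3c2)cc1`: 9.28

In a physicochemical assay for acid dissociation, compound 1 gives 9.28, and compound 2 gives 9.28. The two values lie within the scatter of each other, so compound 1 stands level with compound 2 and no change is shown between them. Going by the values given here, no step between measured compounds is available to lean on. Compound 3 `c1ccc(Oc2ccc3c(NCCCNCc4ccco4)ccnc3c2)cc1` differs from compound 1 by hydrogen in place of methoxy on an aromatic carbon, placed on the phenoxy ring while the rest of the shared core is unchanged. The step of no change at the digits printed from compound 1 to compound 3 (within the scatter) is expected to be none beyond the scatter. Compound 3 is estimated at 9.28, with a range from 8.9 to 9.65.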

Compound 3, acid dissociation constant: 9.28
Estimate against measurement, compound 3: no gap at the digits printed; measured number inside the range.
By their numbers in this assay, from the lowest: compounds 1, 2 and 3 (each within the scatter of the next).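

In this assay, going by these compounds alone, the exchange of methoxy for hydrogen on the phenoxy ring gives no change at the digits printed from compound 1 to compound 3 (within the scatter) and is the first reading of a single change. At this position, on an aromatic carbon ortho to a large group, losing the methoxy leaves the read-out within the scatter, something the earlier pair, differing in more than one place, could not show. No supporting measurement bears on this result. Going by these compounds, whether an amine or a carboxylic acid at the same position would also leave the read-out within the scatter remains open.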